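The source may hold more compounds than are shown below. What is called first, only, known or untested is meant among the compounds shown, and "the series" means these compounds.

Measured compounds:
compound 1 `COC(=O)C(O)Cn1cnc2c(N)ncnc21` — > 400 ug/mL
compound 2 `Nc1ncnc2c1ncn2CC(O)C(=O)OC1CCCCC1` — 100 ug/mL
compound 3 `CCCCCOC(=O)C(O)Cn1cnc2c(N)ncnc21` — 200 ug/mL

Three esters of the shared core have been tested in a functional assay on PRK cells (Oryctolagus cuniculus) for cytotoxicity; a lower number here means that less compound is tolerated, a higher number that more compound is tolerated. Compound 1 gives only a limit of the assay, > 400 ug/mL, so its number is not known. Compound 2 gives 100 ug/mL, and compound 3 gives 200 ug/mL, the highest of the two actual numbers, with compound 2 nearest to it by a 2.0-fold higher number from compound 2 to compound 3 (0.30 log units; within the scatter), a step that lies within the scatter. From compound 1 the steps run an at least 4.0-fold lower number from compound 1 to compound 2 (0.60 log units; beyond the scatter) and an at least 2.0-fold lower number from compound 1 to compound 3 (0.30 log units; that floor lies within the scatter), the second with a floor inside the scatter.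

Compound 4 `CC(C)COC(=O)C(O)Cn1cnc2c(N)ncnc21` has not yet been measured. It differs from compound 3 by isopropyl in place of butyl on a saturated chain carbon bound to an oxygen next to a carbonyl group. Going by the values given here, the steps that bear on this change are an at least 2.0-fold lower number from compound 1 to compound 3 (0.30 log units; that floor lies within the scatter), which alters the same saturated chain carbon, and a 2.0-fold higher number from compound 2 to compound 3 (0.30 log units; within the scatter), which swaps the group on the oxygen; neither moved the number beyond the scatter. A step of a 1.3-fold higher number from compound 3 to compound 4 (0.10 log units; within the scatter) is therefore expected, a small shift toward a higher number, within the scatter. Compound 4 is expected to give about 250 ug/mL in this assay, between 100 ug/mL and 400 ug/mL.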

Compound 4, minimum cytotoxic concentration: > 400 ug/mL
Compound 4: no number, only a limit (the forecaster's own chance of this, stated with the estimate: 25%); middle value at least 1.6-fold (0.20 log units) away from the limit.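

In this assay compound 4 gives only a limit of the assay, > 400 ug/mL. On the oxygen next to the carbonyl group, pentyl to isobutyl gives an at least 2.0-fold higher number from compound 3 to compound 4 (0.30 log units; that floor lies within the scatter), and cyclohexyl to isobutyl gives an at least 4.0-fold higher number from compound 2 to compound 4 (0.60 log units; beyond the scatter), while the step from compound 1 cannot be read. Compound 1 was the only compound at the limit until now, so the limit is no longer confined to the methyl ester and also holds for the isobutyl ester: the limit of > 400 ug/mL in this assay, at which 2 of the 4 values shown sit.

Compound 3 and compound 4 differ in both branching and chain count, so the compounds shown cannot separate the two, and they give no order between compound 1 and compound 4. On these data alone, how a longer chain such as octyl, a branched group such as tert-butyl, or the free carboxylic acid in place of the ester would read in this assay also remains open.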